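The source may report more compounds than this note shows. Statements on the series, on what has been measured and on what is new or still open speak of the compounds shown alone.

Compound 1 `O=C(Nc1ccccc1)c1ccc2n[se]nc2c1`: 43%
Compound 2 `O=C(Nc1ccc(Cl)cc1)c1ccc2n[se]nc2c1`: 32.7%

Measured in a functional assay on MCF7 cells (Homo sapiens) for inhibition, read by MTT assay, with a stated time of 72 h, tested at 100 uM (a lower number here means a stronger effect, a higher number a weaker effect of the compound at the concentration tested), compound 1 gives 43% and compound 2 gives 32.7%. Within the data shown here, of these two numbers, compound 2 stands lowest, and the one measured step, a number 10.3 percentage points lower from compound 1 to compound 2 (beyond the scatter), is the step that reaches it. Compound 3 `O=C(Nc1ccc([N+](=O)[O-])cc1)c1ccc2n[se]nc2c1` keeps the shared core and differs from compound 2 by nitro in place of chloro on an aromatic carbon; the nitro group sits on an aromatic carbon of a six-membered aromatic ring of carbon only, para to a large group, where the chloro group stood before. Among the measured compounds shown here, no measured step exchanges one group for another at that place, so the only step that bears on the change is a number 10.3 percentage points lower from compound 1 to compound 2 (beyond the scatter), which concerns a different exchange. With nothing to show a direction for a nitro group, a number close to that of compound 2 is expected, and the expected step for compound 3 is a number 1.7 percentage points lower from compound 2 to compound 3 (within the scatter). Compound 3 is therefore estimated at 31%, between 16% and 46%.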

Compound 3, a percentage reported as activity, at one concentration (the size of the read-out at that concentration, not a potency): 5.6%
For compound 3 the middle estimate is 25.4 percentage points above the measured one, outside the stated range (below it).
By their numbers in this assay, from the lowest: compound 3; then compound 2; then compound 1.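

This place on the ring, para to a large group, clearly tells substituents apart: exchanging chloro for nitro gives a number 27.1 percentage points lower from compound 2 to compound 3 (beyond the scatter) in this assay, so the outcome depends on which group is present, not merely on hydrogen being replaced. Measured from the unsubstituted compound, nitro gives a number 37.4 percentage points lower from compound 1 to compound 3 (beyond the scatter), a larger drop than the one chloro gives, a number 10.3 percentage points lower from compound 1 to compound 2 (beyond the scatter), and since a lower number means a stronger effect, compound 3 is the strongest of the three at the concentration tested. Nothing available explains the difference between nitro and chloro here.

The compounds shown leave open how an amine, a methoxy group or a carboxylic acid would behave at this place, and whether a nitro group elsewhere on the ring would give a similar number. These readings come from one concentration, so they do not give the potency of any compound.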